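Swapping the Amide Aryl Group: Chlorophenyl to Trifluoromethylphenyl

This account rests on a few compounds, and the source may have more. Where it says the series, first, only, none or still open, it means among the compounds named here.

Measured compounds:
compound 1 `CN(C)C(=O)c1cc2cnc(Nc3ccc(NC(=O)C4(C(=O)Nc5ccc(F)cc5)CC4)cc3F)nc2n1C1CCCC1`, 6.3%;
compound 2 `CN(C)C(=O)c1cc2cnc(Nc3ccc(NC(=O)C4(C(=O)Nc5cccc(Cl)c5)CC4)cc3)nc2n1C1CCCC1`, 39.3%;
compound 3 `CN(C)C(=O)c1cc2cnc(Nc3ccc(N)cn3)nc2n1C1CCCC1`, 18.8%.

In a functional assay on T47D cells (Homo sapiens) for inhibition, read by CCK-8 assay, with a stated time of 72 h, tested at 1 uM (on this read-out lower numbers stand for less inhibition of growth and higher numbers for more inhibition of growth at the one concentration tested), compound 2 gives the highest of the three numbers. Compound 3 stands closest, and compound 1 stands furthest below it, with both gaps beyond the scatter. Compound 4 `CN(C)C(=O)c1cc2cnc(Nc3ccc(NC(=O)C4(C(=O)Nc5ccc(C(F)(F)F)cc5)CC4)cc3)nc2n1C1CCCC1` is not yet measured. It differs from compound 2 in one place: 4-(trifluoromethyl)phenyl in place of 3-chlorophenyl on an amide-type nitrogen. For the measured compounds named here, no pair among the measured compounds isolates this change, so the direction of the step is uncertain. The step of a number 9.3 percentage points lower from compound 2 to compound 4 (within the scatter) is expected to be small and close to the scatter, but it is estimated with wide uncertainty. Compound 4 is therefore expected to give about 30%, within 8% to 55%.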

Compound 4, percent growth inhibition at one concentration: 29.6%
Estimate against measurement, compound 4: 0.4 percentage points above; low and high end bracket the measured number.
By their numbers in this assay, from the lowest: compound 1; then compound 3; then compounds 4 and 2 (each within the scatter of the next).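

In this assay, placing 4-(trifluoromethyl)phenyl on the amide-type nitrogen in place of 3-chlorophenyl gives a number 9.7 percentage points lower from compound 2 to compound 4 (within the scatter). For the compounds shown here, this is the first pair to isolate this position, and it shows that this particular swap, which brings in a larger group with three fluorines instead of one chlorine, leaves no difference beyond the scatter. Nothing available explains the step or shows how these groups act. As far as these compounds go, what stays open is how a phenyl ring carrying an amine or a carboxylic acid would read at this position. Also open, from the compounds shown here alone, is whether a non-aromatic group, such as cyclohexyl, would hold up there.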